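The source may hold more compounds than are shown below. What is called first, only, known or untested is meant among the compounds shown, and "the series" means these compounds.

Compound 2 `C[C@@H](Nc1nccc(Cl)c1NC(=O)CC#N)c1ccc(-c2cccc(F)c2-c2nnn(C)n2)cc1` stands highest of the three numbers in an in vivo ADME assay on the whole organism for pharmacokinetics, with Canis familiaris (Canis lupus familiaris) as the target, at a dose of 3 mg/kg by the oral route; a lower number here means that a smaller share of the oral dose reaches the circulation, a higher number that a larger share of the oral dose reaches the circulation: compound 2 gives 69%. The nearest is compound 1 `Cc1noc(-c2c(F)cccc2-c2ccc([C@@H](C)Nc3nccc(Cl)c3NC(=O)CC#N)cc2)n1`, which in this assay gives 14%; the furthest is compound 3 `COC(=O)c1ccc(Cl)cc1-c1ccc([C@@H](C)Nc2nccc(Cl)c2NC(=O)CC#N)cc1`, which in this assay gives 2%. Both gaps to compound 2 are beyond the scatter.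

Compound 4 `Cc1nc(-c2c(F)cccc2-c2ccc([C@@H](C)Nc3nccc(Cl)c3NC(=O)CC#N)cc2)no1` differs from compound 2 in one place: 5-methyl-1,2,4-oxadiazol-3-yl in place of 2-methyl-2H-tetrazol-5-yl on an aromatic carbon. The entering group is a different attachment isomer of the oxadiazole carried by compound 1, on the same carbon, ortho to a fluoro group and ortho to a large group. Within the data shown here, one measured step bears on this move: a number 55 percentage points higher from compound 1 to compound 2 (beyond the scatter), in which an oxadiazolyl gave way to the tetrazolyl. Compound 4 reverses that exchange in kind, though to the other oxadiazolyl isomer, so a drop in this assay is expected, of a size that cannot be fixed closely. Among the measured compounds shown here, no measured pair shows whether the two oxadiazolyl isomers behave alike, so the full reversal of the step from compound 1 to compound 2 is not assumed. Compound 4 is therefore expected to show a step of a number 39 percentage points lower from compound 2 to compound 4 (beyond the scatter). The estimate for compound 4 in this assay is 30%, within 8% to 60%.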

Compound 4, oral bioavailability: 25%
For compound 4 the middle estimate is 5 percentage points above the measured one; measured number inside the range.
By their numbers in this assay, from the lowest: compound 3; then compound 1; then compound 4; then compound 2.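

At the aromatic carbon ortho to a fluoro group and ortho to a large group, the result tests the 2-methyl-2H-tetrazol-5-yl against a second oxadiazole: in this assay the exchange gives a number 44 percentage points lower from compound 2 to compound 4 (beyond the scatter), so neither of the two oxadiazolyl groups shown comes close to the tetrazolyl. Among these compounds, the two oxadiazolyl attachment isomers, which the earlier compounds could not separate, also prove not to be equivalent, since a number 11 percentage points higher from compound 1 to compound 4 (beyond the scatter), although this step is modest beside the one from the tetrazolyl. No measurement at hand accounts for this order among the three groups at this carbon.

Still open, on these data alone, is whether the high number of compound 2 belongs to the tetrazole ring as such or to its methylated form, which a tetrazole without the methyl group, a methyl-bearing triazole or a methyl-bearing pyrazole on the same carbon would help settle. Also open, as far as these compounds go, is whether the order of these groups holds when the neighbouring fluoro group gives way to hydrogen or chloro, as all the steps here carry that same fluoro group.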